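A few compounds are considered here, and "the series" means these few. Any claim that something is new, unique, unknown or untested is made for them only; others in the source may bear on it.

Compound 1 `O=C(NCCCNc1cc(-c2cn(-c3ccccc3)nc2-c2cccc(O)c2)ccn1)Nc1ccc(F)cc1` and compound 2 `O=C(NCCCNc1cc(-c2cn(-c3ccccc3)nc2-c2cccc(O)c2)ccn1)Nc1cccc(C(F)(F)F)c1` differ only in the aryl group on an amide-type nitrogen. In a functional assay on NCI-H522 cells (Homo sapiens) for antiproliferative activity, read by sulforhodamine B assay, with a stated time of 48 h (on this read-out lower numbers stand for stronger inhibition and higher numbers for weaker inhibition), compound 1 gives 4030 nM and compound 2 gives 5120 nM, so the two stand level within the usual scatter, and compound 1 has no measured neighbour that is clearly apart from it.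

Compound 3 `COc1cccc(-c2nn(-c3ccccc3)cc2-c2ccnc(NCCCNC(=O)Nc3ccc(F)cc3)c2)c1` keeps the rest of compound 1 but changes the 3-hydroxyphenyl to 3-methoxyphenyl, with methyl in place of hydrogen on an oxygen on an aromatic ring. Within the data shown here, the only measured step, a 1.3-fold higher number from compound 1 to compound 2 (0.10 log units; within the scatter), lies at a different place in the molecule, so it offers weak guidance. Among the measured compounds shown here, no measured compound tests this oxygen, and a step beyond the scatter is therefore not expected in this assay. The estimated step is a 1.2-fold higher number from compound 1 to compound 3 (0.08 log units; within the scatter). For compound 3 the expected value is 4800 nM, with an estimated range from 1900 nM to 12000 nM.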

Compound 3, half-maximal inhibitory concentration: 5070 nM
Compound 3: the middle estimate sits 1.1-fold (0.02 log units) below what was measured; low and high end bracket the measured number.
By their numbers in this assay, from the lowest: compounds 1, 3 and 2 (each within the scatter of the next).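

Swapping the hydrogen on this oxygen for methyl, which turns 3-hydroxyphenyl into 3-methoxyphenyl, gives a 1.3-fold higher number from compound 1 to compound 3 (0.10 log units; within the scatter) in this assay. Among these compounds, the earlier compounds varied only the aryl group on the amide-type nitrogen, so this is the first reading at the oxygen: the hydroxy hydrogen can be replaced by methyl and the two compounds still stand level in this assay. This single pair shows no sign that the free hydroxy matters for the cell read-out, and nothing at hand explains the result.

From the compounds shown here alone, it remains open whether a longer chain on this oxygen, such as ethyl or benzyl, would give a step beyond the scatter. The same holds for an amine or a carboxylic acid in place of the hydroxy, or a plain phenyl with no oxygen at all.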